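A few compounds are considered here, and "the series" means these few. Any claim that something is new, unique, unknown or untested is made for them only; others in the source may bear on it.

In a functional assay on NCI-H322 cells (Homo sapiens) for antiproliferative activity (on this read-out lower numbers stand for stronger inhibition of growth and higher numbers for weaker inhibition of growth), compound 1 `COCCCCCCCCCCCCCCC/C=C1\CC(CO)(COC(=O)C(C)(C)C)OC1=O` gives > 10 ug/mL, which is a limit and not a number. Compound 2 `COC(=O)CCCCCCCCCCCCCC/C=C1\CC(CO)(COC(=O)C(C)(C)C)OC1=O` gives > 10 ug/mL, also a limit. Compound 3 `CCCCCCCCC(O)CCCCCC/C=C1\CC(CO)(COC(=O)C(C)(C)C)OC1=O` gives > 10 ug/mL, again only a limit, so it cannot be ranked against the other two. Within the data shown here, the series so far therefore rests on (the limit of > 10 ug/mL in this assay, at which 3 of the 3 values shown sit).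

The next change leads to compound 4 `CCCCCOCCCCCCC/C=C1\CC(CO)(COC(=O)C(C)(C)C)OC1=O`: (pentyloxy)methyl in place of 1-hydroxynonyl on a saturated chain carbon, six bonds along the chain from a double-bonded chain carbon. In words, this is (pentyloxy)methyl in place of 1-hydroxynonyl on a saturated chain carbon, six bonds along the chain from a double-bonded chain carbon.

Among the measured compounds shown here, two measured steps bear on it. The closer one, at the same place on the chain, is a step that the two limits leave unreadable from compound 1 to compound 3. The other is a step that the two limits leave unreadable from compound 1 to compound 2. Neither has a readable size, so neither supports an expected shift in either direction. The expected step, with no direction beyond the scatter, is a step that the limit leaves unreadable from compound 3 to compound 4. A further limit reading is the likeliest outcome. For compound 4 the estimate is 15 ug/mL, with an expected range of 7 ug/mL to 30 ug/mL.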

Compound 4, concentration for 50% growth inhibition: 9.52 ug/mL
The estimate for compound 4 lay 1.6-fold (0.20 log units) above the measured number; measured number inside the range.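

In this assay compound 4 gives 9.52 ug/mL, the only number among the compounds shown, so the chain now has one readable value at six bonds along from the double-bonded chain carbon. The rest of the series offers only a limit: the limit of > 10 ug/mL in this assay, at which 3 of the 4 values shown sit. Replacing 1-hydroxynonyl with (pentyloxy)methyl gives an at least 1.0-fold lower number from compound 3 to compound 4 (0.02 log units; that floor lies within the scatter), while the two pentyloxy comparisons give an at least 1.0-fold lower number from compound 2 to compound 4 (0.02 log units; that floor lies within the scatter) and an at least 1.0-fold lower number from compound 1 to compound 4 (0.02 log units; that floor lies within the scatter), so each step is bounded on one side only and none is shown to exceed the scatter.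

As far as these compounds go, the true size of all three steps stays open, and with it whether this change matters at all. Also open, from the compounds shown here alone, is how an amine or a carboxylic acid in place of (pentyloxy)methyl, at the same place on the chain, would read in this assay.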